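Thiophen-3-yl for phenyl on a shared thiocarbamate core

This account rests on a few compounds, and the source may have more. Where it says the series, first, only, none or still open, it means among the compounds named here.

The series shares a core in which a thiocarbamate carries a pyridinylmethyl amine and a thioether chain ending in an aromatic ring. Compound 1 `S=C(NCc1cccnc1)SCCc1nnn[nH]1` sits at the tetrazole end of that chain. In a functional assay on SK-BR-3 cells (Homo sapiens) for cytotoxicity, read by resazurin assay, with a stated time of 72 h (a lower number here means a stronger inhibitor, a higher number a weaker inhibitor), compound 1 gives only a limit, > 100000 nM, the value described by the limit of > 100000 nM in this assay, at which 1 of the 3 values shown sits. Compound 2 `S=C(NCc1cccnc1)SCCc1nc2ccccc2s1` carries a benzothiazole and in this assay compound 2 gives 1390 nM. Compound 3 `S=C(NCc1cccnc1)SCCc1nnc(-c2ccccc2)o1` carries a phenyl-substituted oxadiazole; in this assay compound 3 gives 580 nM, the lowest of the two numbers shown, and its gap to compound 2 lies beyond the scatter.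

Compound 4 `S=C(NCc1cccnc1)SCCc1nnc(-c2ccsc2)o1` differs from compound 3 by thiophen-3-yl in place of phenyl on an aromatic carbon. Going by the values given here, no step between two measured compounds matches this exchange, so the expectation rests on the general closeness of the two groups. The step from compound 3 to compound 4 is expected to be small, a 1.1-fold higher number from compound 3 to compound 4 (0.05 log units; within the scatter), not beyond the scatter in either direction. Compound 4 is therefore estimated to give 650 nM in this assay, within a range from 250 nM to 1700 nM.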

Compound 4, half-maximal inhibitory concentration: 1030 nM
Estimate against measurement, compound 4: 1.6-fold (0.20 log units) below; the range from low to high includes it.
By their numbers in this assay, from the lowest: compounds 3, 4 and 2 (each within the scatter of the next, the first and the last beyond it). At a limit, above all of these: compound 1.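

On the aromatic carbon of the five-membered aromatic ring with 2 nitrogen and 1 oxygen, next to the ring nitrogen and the ring oxygen, putting thiophen-3-yl in place of phenyl gives a 1.8-fold higher number from compound 3 to compound 4 (0.25 log units; within the scatter) in this assay. This is the only step shown between two compounds that differ in one place, and it shows that a five-membered aromatic ring with sulfur can stand at this position in place of the six-membered carbon ring without a difference that exceeds the scatter. The data shown offer no measured explanation for this result.

On these data alone, whether thiophen-2-yl, a cyclohexyl ring or an amine on the same carbon would stay within the scatter of compound 3 remains open. Every compound shown also keeps the pyridinylmethyl amine, so what a different group there would do remains open as well.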